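A few compounds are considered here, and "the series" means these few. Any claim that something is new, unique, unknown or untested is made for them only; others in the source may bear on it.

Series notes. Compound 1 `COc1ccc(Nc2nc(/C=C/c3cc(OC)c(OC)c(OC)c3)nc3ccsc23)cc1`, compound 2 `COc1cc(/C=C/c2nc(Nc3ccc(O)cc3)c3sccc3n2)cc(OC)c1OC` and compound 3 `COc1ccc(CNc2nc(/C=C/c3cc(OC)c(OC)c(OC)c3)nc3ccsc23)cc1` share one core and differ only at the substituent on the ring nitrogen. In an ADME assay on RAW264.7 cells (Mus musculus) for cytotoxicity, read by MTT assay (a lower number here means a stronger inhibitor, a higher number a weaker inhibitor), compound 1 gives no number but a limit of > 50000 nM in this assay. Compound 2 likewise gives only a limit of > 50000 nM in this assay. Compound 3 also gives only a limit of > 50000 nM in this assay. Compound 3 therefore stands where every value of the set stands, as the limit of > 50000 nM in this assay, at which 3 of the 3 values shown sit, records. Within the data shown here, the measured steps are a step that the two limits leave unreadable from compound 1 to compound 2, a step that the two limits leave unreadable from compound 1 to compound 3 and a step that the two limits leave unreadable from compound 2 to compound 3; none of them has a readable size, so no step in this assay has yet been resolved in either direction. Compound 4 `COc1cc(/C=C/c2nc(NCc3ccncc3)c3sccc3n2)cc(OC)c1OC` is the next member. Its change from compound 3 is pyridin-4-yl in place of 4-methoxyphenyl on a saturated chain carbon bound to a nitrogen on an aromatic ring, a swap of the aromatic ring on the chain carbon. The three measured steps bear on it only in that each ran between two values at the same limit; none gives a direction or a size. Compound 4 is expected to remain at that limit as well, the expected step being a step that the limit leaves unreadable from compound 3 to compound 4 in this assay. The estimate for compound 4 in this assay is 80000 nM, with a range from 30000 nM to 250000 nM around it.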

Compound 4, half-maximal inhibitory concentration: > 50000 nM
Compound 4: no number, only a limit; the forecaster's own chance of this, stated with the estimate: 85%; the middle value lies beyond the limit too.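

The steps from compound 1, compound 2 and compound 3 to compound 4 cannot be read in this assay, as each runs between two limits: the limit of > 50000 nM in this assay, at which 4 of the 4 values shown sit. The compounds shown leave open whether any substituent on the ring nitrogen of the shared core gives a measurable value in this assay, and how large a step at that place would be.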